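The compounds below may be only part of what the source reports. "The series", "measured", "known", "first", "only" and "open" are said of these compounds alone.

Compound 2, whose structure is `N#Cc1ccc(-c2cnc3[nH]cc(-c4nnc(-c5ccc(Cl)cc5)o4)c(=O)c3c2)cc1`, was tested in a functional assay on HCT-116 cells (Homo sapiens) for inhibition, read by MTT assay, with a stated time of 24 h, tested at 10 uM (on this read-out higher numbers stand for more inhibition of growth at the one concentration tested and lower numbers for less inhibition of growth), and gave 18.3%. Among the two numbers measured so far it heads the list, but only nominally: the one other compound measured, compound 1 with the structure `CS(=O)(=O)c1ccc(-c2cnc3[nH]cc(-c4nnc(-c5ccc(Cl)cc5)o4)c(=O)c3c2)cc1`, gave 17% in this assay, and the gap between them is within the scatter of the method. Within the data shown here, the single comparison available, a number 1.3 percentage points higher from compound 1 to compound 2 (within the scatter), came from swapping a cyano for a methylsulfonyl group on an aromatic carbon and changed nothing beyond the scatter.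

Compound 3, with the structure `O=c1c(-c2nnc(-c3ccc(Cl)cc3)o2)c[nH]c2ncc(-c3cccnc3)cc12`, is not yet measured. It differs from compound 2 in one place: pyridin-3-yl in place of 4-cyanophenyl on an aromatic carbon. Among the measured compounds shown here, the only step that bears on this is the one from compound 1 to compound 2, which also exchanged the group on that same aromatic carbon and was within the scatter. On that basis the estimated step of a number 0.3 percentage points lower from compound 2 to compound 3 (within the scatter) is expected to be no more than scatter, with no direction favoured. Compound 3 is therefore expected to give about 18% in this assay, with a likely range from 7% to 30%.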

Compound 3, percent growth inhibition at one concentration: 11.8%
Compound 3: the middle estimate sits 6.2 percentage points above what was measured; low and high end bracket the measured number.
By their numbers in this assay, from the lowest: compounds 3, 1 and 2 (each within the scatter of the next).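

The exchange for pyridin-3-yl on this aromatic carbon gives a number 6.5 percentage points lower from compound 2 to compound 3 (within the scatter) and a number 5.2 percentage points lower from compound 1 to compound 3 (within the scatter) when read in this assay at this position. The earlier pair compared two phenyl rings bearing different substituents, whereas compound 3 carries a ring with a nitrogen in it and no further substituent, and this still leaves all three compounds within the scatter of one another. On this read-out, then, neither the nitrogen in the ring nor the loss of the cyano or methylsulfonyl group sets a compound apart, and no measurement at hand accounts for where the individual numbers fall.

What stays open is whether any group on this carbon can move the number beyond the scatter, as every group shown here is a six-membered aromatic ring attached directly to the core. An amine, a carboxylic acid or a longer alkyl chain at this position would put that question to a real test, with a group of a different kind from the three aromatic rings compared so far.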